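The source may report more compounds than this note shows. Statements on the series, on what has been measured and on what is new or still open speak of the compounds shown alone.

Measured so far in a functional assay on HeLa cells (Homo sapiens) for cytotoxicity, read by MTT assay; on this read-out higher numbers stand for weaker inhibition and lower numbers for stronger inhibition: compound 1 `CC[C@@](C)(O)CC(=O)O[C@H](CC=C(C)C)C1=CC(=O)c2c(O)ccc(O)c2C1=O` gives 17900 nM; compound 2 `CCC(CO[C@H](CC=C(C)C)C1=CC(=O)c2c(O)ccc(O)c2C1=O)OC(C)=O` gives 44000 nM; compound 3 `CC(C)=CC[C@@H](OC(=O)c1ccco1)C1=CC(=O)c2c(O)ccc(O)c2C1=O` gives 80300 nM.

Compound 1 stands lowest of these three. Its nearest neighbour is compound 2, with a 2.5-fold higher number from compound 1 to compound 2 (0.39 log units; beyond the scatter); the furthest is compound 3, with a 4.5-fold higher number from compound 1 to compound 3 (0.65 log units; beyond the scatter). Compound 4 `CCCC(C)(O)CC(=O)O[C@H](CC=C(C)C)C1=CC(=O)c2c(O)ccc(O)c2C1=O` differs from compound 1 by a single change: 1-hydroxy-1-methylbutyl in place of 1-hydroxy-1-methylpropyl on a saturated chain carbon bound to a carbonyl carbon. Within the data shown here, of the measured steps, none adds one carbon to a chain; both replace the whole ester group, and the one step of that kind, a 1.8-fold higher number from compound 2 to compound 3 (0.26 log units; within the scatter), is small. Among the measured compounds shown here, no measured step therefore speaks directly to this change, and the expectation in this assay is a step of no more than the scatter, in no settled direction. The estimated step is a 1.1-fold higher number from compound 1 to compound 4 (0.05 log units; within the scatter). Compound 4 is thus expected to give about 20000 nM, within 9000 nM to 45000 nM.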

Compound 4, half-maximal inhibitory concentration: 72000 nM
The estimate for compound 4 lay 3.6-fold (0.56 log units) below the measured number; the whole stated range lies below it.
By their numbers in this assay, from the lowest: compound 1; then compounds 2, 4 and 3 (each within the scatter of the next).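

In this assay, this position does not tolerate every small change: adding one carbon to the chain, 1-hydroxy-1-methylbutyl in place of 1-hydroxy-1-methylpropyl, gives a 4.0-fold higher number from compound 1 to compound 4 (0.60 log units; beyond the scatter) on the number. The longer chain brings compound 4 level with the other two esters, since a 1.1-fold lower number from compound 3 to compound 4 (0.05 log units; within the scatter) and a 1.6-fold higher number from compound 2 to compound 4 (0.21 log units; within the scatter) are both read as no real difference. No measurement available here explains why one carbon has this effect.

Going by these compounds, it remains open whether a still longer chain, such as 1-hydroxy-1-methylpentyl, would raise the number further. An amine in place of the hydroxy group on this chain is also untested among the compounds shown.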